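A few compounds are considered here, and "the series" means these few. Any claim that something is new, unique, unknown or untested is made for them only; others in the source may bear on it.

Working notes on the series.

Two members have numbers in a functional assay on cells for agonist activity at melatonin receptor type 1A (Homo sapiens), read by GTPgammaS binding, with a stated time of 30 min; on this read-out lower numbers stand for smaller maximal responses and higher numbers for larger maximal responses. Compound 1 `CC(=O)NCCN(C)c1cccc(OCCCCCCN)c1` carries a free amine at the end of its chain; in this assay compound 1 reaches 0.34. Compound 2 `CC(=O)NCCN(C)c1cccc(OCCCCCCOc2cccc(OC(=O)NC3CCCCC3)c2)c1` ends instead in a second aromatic ring bearing a (cyclohexylcarbamoyl)oxy group, and in this assay compound 2 reaches 0.71, the higher of the two numbers and a gap beyond the scatter from compound 1.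

Compound 3 `CC(=O)NCCN(C)c1cccc(OCCCCCCOc2cccc(O)c2)c1` is the next structure, not yet measured. It differs from compound 2 in one place: hydrogen in place of cyclohexylcarbamoyl on an oxygen on an aromatic ring, so the (cyclohexylcarbamoyl)oxy becomes a hydroxy. For the measured compounds named here, no measured pair shows this exact change. With only two points, the expectation is a moderate downward step, a number 0.16 lower from compound 2 to compound 3 (beyond the scatter), since the smaller end group in compound 1 gave 0.34. Compound 3 is thus estimated at 0.55, within 0.35 to 0.75.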

Compound 3, intrinsic activity: the largest response reached, as a fraction of the reference agonist's: 0.62
Compound 3: middle estimate off by 0.070, on the low side, and the stated range covers the measured number.
By their numbers in this assay, from the lowest: compound 1; then compounds 3 and 2 (each within the scatter of the next).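

In this assay, hydroxy in place of (cyclohexylcarbamoyl)oxy gives a number 0.090 lower from compound 2 to compound 3 (within the scatter), so across this pair the cyclohexylcarbamoyl group on the oxygen on the aromatic ring makes no difference that can be told from scatter. The maximal response of compound 2 therefore does not depend on that whole group being present, at least in a comparison with a hydroxy at this place. With 3-hydroxyphenoxy in place of amino at the chain end, the result is a number 0.28 higher from compound 1 to compound 3 (beyond the scatter), so the separation from the free amine persists without the cyclohexylcarbamoyl group.

Nothing available explains either step. Still open, going by these compounds, is whether a smaller group on this oxygen, such as methoxy, or a shorter or longer chain than the hexyl-length one shared here, would hold the response at this level.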